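The source may report more compounds than this note shows. Statements on the series, on what has been measured and on what is new or still open speak of the compounds shown alone.

Compound 1, `CCCCCCCCCCCCCCCCOP(=O)(O)OCCSC(=S)N1CCCCC1`: 14700 nM
Compound 2, `CCCCCCCCCCOP(=O)(O)OCCSC(=S)N1CCCC1`: 46100 nM

In a functional assay on DU-145 cells (Homo sapiens) for inhibition, read by MTT assay, with stated times of 18 h and 4 h (on this read-out higher numbers stand for weaker inhibition and lower numbers for stronger inhibition), compound 1 gives 14700 nM, the lowest of the two numbers, while compound 2 gives 46100 nM, a gap beyond the scatter. Compound 3, `CCCCCCOP(=O)(O)OCCSC(=S)N1CCCCC1`, has not been measured. It differs from compound 1 in one place: hydrogen in place of decyl on a saturated chain carbon, six bonds along the chain from an oxygen on an unsaturated carbon. Compound 2 carries a shorter chain than compound 1 and gives a higher number, so a further shortening is expected to push the number higher again, a step beyond the scatter. For compound 3 the expected value in this assay is 100000 nM, within 30000 nM to 300000 nM, an expected step of a 6.8-fold higher number from compound 1 to compound 3 (0.83 log units; beyond the scatter).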

Compound 3, half-maximal inhibitory concentration: > 100000 nM
Compound 3: only a limit was reported; the forecaster's own chance of this, stated with the estimate: 25%; the middle value lies on the limit itself.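

Compound 1 and compound 2 differ in more than one place, so that pair could not single out the chain. Hydrogen in place of decyl on this saturated chain carbon, with nothing else changed, gives an at least 6.8-fold higher number from compound 1 to compound 3 (0.83 log units; beyond the scatter) in this assay, so chain length alone matters at this position. The value of compound 3 is a limit, not a number: the limit of > 100000 nM in this assay, at which 1 of the 3 values shown sits.

Going by these compounds, whether a longer chain would lower the number further remains open. So does whether an amine at the end of the chain would keep the activity of compound 1.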